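Notes on compound 3 in the cytotoxicity series

This account rests on a few compounds, and the source may have more. Where it says the series, first, only, none or still open, it means among the compounds named here.

Measured in a functional assay on NALM-6 cells (Homo sapiens) for cytotoxicity, with a stated time of 72 h; a higher number here means that more compound is needed for the effect, a lower number that less compound is needed:
- Compound 1 `C=C[C@@](C)(/C=C/c1ccc(OCc2ccccc2)cc1)CCC=C(C)C`: > 43400 nM (a limit)
- Compound 2 `C=C[C@@](C)(/C=C/c1ccc(Nc2c(F)cc(F)cc2F)cc1)CCC=C(C)C`: > 43400 nM (a limit)

Compound 2 stands at a limit and not at a number, and compound 1 stands at the same one: the limit of > 43400 nM in this assay, at which 2 of the 2 values shown sit. No order can be read between the two.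

Compound 3 `C=C[C@@](C)(/C=C/c1ccc(Nc2ccc(Cl)cc2)cc1)CCC=C(C)C` carries 4-chlorophenyl in place of 2,4,6-trifluorophenyl on a nitrogen on an aromatic ring.

For the measured compounds named here, the series holds no measured step by which to size this change. No step beyond the scatter is expected in this assay, in either direction. That expectation rests on compound 2, whose > 43400 nM is a limit. The expected step is an at least 1.0-fold lower number from compound 2 to compound 3 (0.03 log units; that floor lies within the scatter). A further limit is the likeliest report for compound 3. If a number is reported, the estimate for compound 3 is 40000 nM, with an expected range from 15000 nM to 80000 nM.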

Compound 3, half-maximal effective concentration: > 43400 nM
Compound 3 gave a limit, no number; the forecaster's own chance of this, stated with the estimate: 65%; at least 1.0-fold (0.03 log units) between middle value and limit.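

Compound 3 gives a limit and not a number, as do compound 1 and compound 2, so no step among the three can be read: the limit of > 43400 nM in this assay, at which 3 of the 3 values shown sit.

The compounds shown leave open which change to the shared core, if any, would give a number rather than a limit in this assay.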